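Swapping the aryl ketone partner in a chalcone-like pyrazole pair

The source may hold more compounds than are shown below. What is called first, only, known or untested is meant among the compounds shown, and "the series" means these compounds.

Measured compounds:
compound 1, `COc1cc(-c2cc(/C=C/C(=O)c3ccc(Cl)c(Cl)c3)[nH]n2)cc(OC)c1OC`, 93%
compound 2, `COc1ccc(-c2cc(/C=C/C(=O)c3ccc(N)cc3)[nH]n2)cc1OC`, 107%

In a functional assay on TK-10 cells (Homo sapiens) for cytotoxicity, read by sulforhodamine B assay, with a stated time of 48 h, tested at 1 uM (a higher number here means a weaker effect of the compound at the concentration tested, a lower number a stronger effect), compound 1 gives 93%, the lowest of the two numbers, and compound 2 stands at 107%, a gap beyond the usual scatter. Both readings sit near the level of untreated cells, so neither compound shows a strong effect at the concentration tested. Compound 3, `COc1ccc(C(=O)/C=C/c2cc(-c3cc(OC)c(OC)c(OC)c3)n[nH]2)cc1OC`, has not yet been measured in this assay. It differs from compound 1 in one place: 3,4-dimethoxyphenyl in place of 3,4-dichlorophenyl on a carbonyl carbon. Among the compounds with values here, no step between measured compounds covers this change, so there is no directly comparable pair to lean on. Given that compound 1 is itself weak at 93%, the step of a number 3 percentage points higher from compound 1 to compound 3 (within the scatter) is expected to be small, with no clear direction beyond the scatter. Compound 3 is therefore estimated at 96%, within a range from 82% to 110%.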

Compound 3, a percentage reported as activity, at one concentration (the size of the read-out at that concentration, not a potency): 71%
Beside the measured number, compound 3's estimate is 25 percentage points above it; the measured number lies below the stated range.
By their numbers in this assay, from the lowest: compound 3; then compound 1; then compound 2.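

In this assay, within the data shown here, 3,4-dimethoxyphenyl in place of 3,4-dichlorophenyl on a carbonyl carbon gives a number 22 percentage points lower from compound 1 to compound 3 (beyond the scatter), the first step in this set that can be read as a change in one place. It shows that this position can move the read-out on an otherwise unchanged core, and that the group carrying hydrogen-bond acceptors gives the stronger effect of this pair at the one concentration tested. Nothing at hand accounts for the direction or size of this step.

The compounds shown leave open whether a phenyl bearing hydroxyl groups or a carboxylic acid on the same carbonyl carbon would follow compound 3 or compound 1. They also leave open whether the same exchange would give a similar step on the core of compound 2.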